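Swapping a long ester chain for one bromine

A few compounds are considered here, and "the series" means these few. Any claim that something is new, unique, unknown or untested is made for them only; others in the source may bear on it.

In a functional assay on MCF-A cells (Homo sapiens) for cytotoxicity (a lower number here means a stronger inhibitor of growth, a higher number a weaker inhibitor of growth), compound 1 `COc1ccc(C2=C(c3ccc(SC)cc3)CC3CCCN3C2=O)cc1O` gives 5000 nM while compound 2 `COc1ccc(C2=C(c3ccc(SC)cc3)CC3CCCN3C2=O)cc1OC(=O)CNC(=O)OC(C)(C)C` gives 6000 nM and compound 3 `COc1ccc(C2=C(c3ccc(SC)cc3)CC3CCCN3C2=O)cc1OC(=O)C1CCCN1C(=O)OC(C)(C)C` gives 4000 nM on the same core. Compound 2 therefore stands level with the other two, within the scatter of each, so its number cannot be ranked against theirs.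

Compound 4 `COc1ccc(C2=C(c3ccc(SC)cc3)CC3CCCN3C2=O)cc1Br` has not yet been measured. Its difference from compound 2 is one bromine atom in place of a group of 12 heavy atoms (7 carbon, 1 nitrogen, 4 oxygen; no ring), on an aromatic carbon at a place ortho to a methoxy group.

Going by the values given here, two measured steps bear on this place. Putting the ester chain on the oxygen gave a 1.2-fold higher number from compound 1 to compound 2 (0.08 log units; within the scatter) and exchanging the end of that chain gave a 1.5-fold lower number from compound 2 to compound 3 (0.18 log units; within the scatter) with both inside the scatter. So a hydrogen and two large groups on this oxygen have given much the same number. Among the compounds with values here, no measured compound carries a bromine here, and the data offer no direction for this swap.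

A change beyond the scatter is therefore not expected in this assay for this swap. The estimated step is a 1.5-fold lower number from compound 2 to compound 4 (0.18 log units; within the scatter) and it could fall either way. Compound 4 is expected at 4000 nM (estimated range 1200 nM to 12000 nM).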

Compound 4, concentration for 50% growth inhibition: 6000 nM
Beside the measured number, compound 4's estimate is 1.5-fold (0.18 log units) below it; the measured number falls inside the stated range.
By their numbers in this assay, from the lowest: compounds 3, 1, 2 and 4 (each within the scatter of the next).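

In this assay, a single bromine atom in place of the whole ester chain gives no change at the digits printed from compound 2 to compound 4 (within the scatter), so removing all of that chain, with its carbonyl groups and its tert-butoxycarbonyl end, does not move the number beyond the scatter. Bromo in place of hydroxy gives a 1.2-fold higher number from compound 1 to compound 4 (0.08 log units; within the scatter), which is a different kind of test: compounds 1, 2 and 3 all carry an oxygen on this aromatic carbon, and compound 4 is the first here with no oxygen at that place. Across these four compounds, then, neither the size of the group nor the presence of that oxygen has shifted the number beyond the scatter, although no measurement here gives a reason for this.

What the compounds shown leave open is whether any group on this aromatic carbon can shift the number beyond the scatter in either direction. An amine, a carboxylic acid or the free amino ester without its tert-butoxycarbonyl end would test this further, since a flat result across a hydroxy, two esters and a bromine says nothing yet about groups of those kinds.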